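Benzylsulfonyl in place of (furan-2-yl)carbonyl

The compounds below may be only part of what the source reports. "The series", "measured", "known", "first", "only" and "open" are said of these compounds alone.

Measured in a functional assay on K562 cells (Homo sapiens) for cytotoxicity, read by MTT assay; on this read-out lower numbers stand for stronger inhibition and higher numbers for weaker inhibition
- compound 1 `C=CCOc1cc(/C=C/C(=O)c2ccc(OC)c3c2OC(C)(C)C=C3)ccc1OC` gives > 10000 nM as a limit of the assay
- compound 2 `COc1ccc(/C=C/C(=O)c2ccc(OC)c3c2OC(C)(C)C=C3)cc1OC(=O)c1ccco1` gives 450 nM

Going by the values given here, compound 2 with 450 nM holds the only actual number so far. Among the compounds with values here, compound 3 `COc1ccc(/C=C/C(=O)c2ccc(OC)c3c2OC(C)(C)C=C3)cc1OS(=O)(=O)Cc1ccccc1` carries benzylsulfonyl in place of (furan-2-yl)carbonyl on an oxygen on an aromatic ring and this exchange has no measured precedent. Within the data shown here, the one measured step at this oxygen is an at least 22-fold lower number from compound 1 to compound 2 (1.34 log units; beyond the scatter) and it shows that the value can move far with the group there. In this assay a moderate move toward weaker inhibition is therefore expected, estimated as a 3.3-fold higher number from compound 2 to compound 3 (0.52 log units; beyond the scatter) for this exchange. For compound 3 the expected value is 1500 nM with an estimated range from 300 nM to 8000 nM in this series.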

Compound 3, half-maximal inhibitory concentration: > 10000 nM
Compound 3: only a limit was reported; the forecaster's own chance of this, stated with the estimate: 15%; middle value at least 6.6-fold (0.82 log units) away from the limit.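

In this assay benzylsulfonyl in place of (furan-2-yl)carbonyl gives an at least 22-fold higher number from compound 2 to compound 3 (1.34 log units; beyond the scatter) and removes the measurable activity of compound 2. An aromatic ring in the group on this oxygen is therefore not sufficient, since benzylsulfonyl also carries one. The size of this step is only a lower bound: the limit of > 10000 nM in this assay, at which 2 of the 3 values shown sit.

The step between compound 1 and compound 3 cannot be read, as both values are limits. From the compounds shown here alone, whether the activity depends on the carbonyl or on the furan ring stays open; benzoyl and furan-2-ylsulfonyl on this oxygen would separate the two.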